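A Diethylamide Follows Two Flat Benzyl Esters

A few compounds are considered here, and "the series" means these few. Any claim that something is new, unique, unknown or untested is made for them only; others in the source may bear on it.

Measured in a functional assay on PC-3 cells (Homo sapiens) for cytotoxicity, read by colorimetric assay and MTT assay; on this read-out lower numbers stand for stronger inhibition and higher numbers for weaker inhibition:
Compound 1 `COc1ccc(-c2cc3c(OC)cc(OC)cc3n(CC(=O)OCc3ccccc3)c2=O)cc1`: 10000 nM
Compound 2 `COc1ccc(-c2cc3c(OC)cc(OC)cc3n(CCC(=O)OCc3ccccc3)c2=O)cc1`: 10000 nM

Among the measured compounds shown here, on these numbers, compound 2 gives 10000 nM and stands level with compound 1, the only other compound measured. The next compound, compound 3 `CCN(CC)C(=O)CCn1c(=O)c(-c2ccc(OC)cc2)cc2c(OC)cc(OC)cc21`, keeps the shared core and changes only the group on the carbonyl carbon: diethylamino in place of benzyloxy on a carbonyl carbon. Diethylamino thus stands in place of benzyloxy, turning (benzyloxycarbonyl)methyl into (diethylcarbamoyl)methyl.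

Just one measured step bears on this change, and only indirectly: no change at the digits printed from compound 1 to compound 2 (within the scatter). That step replaces benzyloxycarbonyl with (benzyloxycarbonyl)methyl and leaves benzyloxy in place. For the measured compounds named here, no measured compound shows what happens when benzyloxy is replaced, so the data give no direction for such a change. Going by the values given here, with only that flat step to go on, no shift beyond the scatter is expected in this assay, although a real move either way cannot be excluded. The expected step is no change at the digits printed from compound 2 to compound 3 (within the scatter). For compound 3 the estimated value is 10000 nM, with an expected range from 4000 nM to 20000 nM.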

Compound 3, half-maximal inhibitory concentration: 10000 nM
For compound 3 middle estimate and measured number coincide at the digits printed, within the range that was stated.
By their numbers in this assay, from the lowest: compounds 1, 2 and 3 (each within the scatter of the next).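

In this assay, among the compounds shown here, the replacement of benzyloxy by diethylamino on a carbonyl carbon gives no change at the digits printed from compound 2 to compound 3 (within the scatter) and is the first measured change to this end of the side chain; it shows that an ester group carrying a six-membered aromatic ring can give way to a ringless amide group with no shift beyond the scatter. Read against the shorter ester, the replacement of benzyloxycarbonyl by (diethylcarbamoyl)methyl on a saturated chain carbon bound to an aromatic nitrogen alters the chain and the end group together, and it gives no change at the digits printed from compound 1 to compound 3 (within the scatter) in the same read-out. No supporting data are available to explain why these values coincide.

The compounds shown leave open whether a free carboxylic acid or a morpholine amide on this carbonyl carbon would read any differently in this assay. They also leave open whether a longer chain carrying the diethylcarbamoyl group, or a primary amine at the end of that chain, would stand apart from these three compounds.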